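The compounds below may be only part of what the source reports. "The series", "measured", "known", "first", "only" and "open" are said of these compounds alone.

Measured compounds:
Compound 1, `COc1ccc(-c2cc(=O)c3c(OC)cc(OC)cc3n2C)cc1`: 30000 nM
Compound 2, `COc1ccc(-c2[nH]c3cc(OC)cc(OC)c3c(=O)c2I)cc1`: 49400 nM
Compound 3, `COC(=O)c1cc(=O)c2cc(N)ccc2[nH]1`: > 33700 nM

All three were tested in a functional assay on KOPN-8 cells (Homo sapiens) for antiproliferative activity, with a stated time of 72 h; a higher number here means that more compound is needed for the effect, a lower number that less compound is needed. Of the two numbers obtained, compound 1 gives the lowest with 30000 nM, while compound 2 gives 49400 nM, a gap that lies within the scatter of repeated measurements, so the two cannot be placed in order. Compound 3 stands at the limit of > 33700 nM in this assay, at which 1 of the 3 values shown sits, which is a limit of the assay and not a number.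

Compound 4, `COc1ccc(-c2cc(=O)c3c(OC)cc(OC)cc3n2S(=O)(=O)c2ccc(C#N)cc2)cc1`, has not yet been measured. It differs from compound 1 in one place: (4-cyanophenyl)sulfonyl in place of methyl on an aromatic nitrogen. Among the compounds with values here, no step between two measured compounds of this set touches that position, so the data give no measured size for such a change in this assay. The step expected here is a 1.2-fold lower number from compound 1 to compound 4 (0.08 log units; within the scatter), not beyond the scatter in either direction. For compound 4 the estimated value is 25000 nM, with a range from 5000 nM to 100000 nM.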

Compound 4, half-maximal effective concentration: > 17200 nM
Compound 4 ended at the assay's limit; the forecaster's own chance of this, stated with the estimate: 30%; the middle value does not contradict the limit.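

In this assay compound 4 gives > 17200 nM, which is a limit of the assay and not a number, so no step can be read from compound 1 to compound 4. The compounds shown leave open how far (4-cyanophenyl)sulfonyl in place of methyl on an aromatic nitrogen shifts the number in this assay.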